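Dropping the Methoxy Group from a Biaryl Ether Furoic Acid

This account rests on a few compounds, and the source may have more. Where it says the series, first, only, none or still open, it means among the compounds named here.

Compound 1, `COc1ccc(-c2ccc(OCc3cc(C(=O)NS(=O)(=O)c4ccccc4)oc3C)cc2)c(C)c1`, gives 21 nM in an assay on cells for displacement of a labelled ligand from prostaglandin E2 receptor EP4 subtype (Homo sapiens), read by scintillation counting; a lower number here means a stronger inhibitor, a higher number a weaker inhibitor.
Compound 2, `COc1ccccc1-c1ccc(OCc2cc(C(=O)O)oc2C)cc1`, gives 1600 nM in this assay.
Compound 3, `Cc1oc(C(=O)O)cc1CCOc1ccc(-c2ccccc2)cc1`, gives 3800 nM in this assay.

Among these three numbers, compound 2 stands second highest. Its nearest neighbour is compound 3, whose number is higher by a gap beyond the scatter; the furthest is compound 1, whose number is far lower, also beyond the scatter. Compound 4, `Cc1oc(C(=O)O)cc1COc1ccc(-c2ccccc2)cc1`, has not yet been measured. It differs from compound 2 in one place: hydrogen in place of methoxy on an aromatic carbon. Read one bond further out, the change is 2-methoxyphenyl to phenyl. Compound 3 also carries a plain phenyl, though on a longer linker, and its number sits above that of compound 2. For compound 4 the step of a 1.9-fold higher number from compound 2 to compound 4 (0.27 log units; within the scatter) in this assay is therefore expected to be modest and toward a weaker inhibitor. Compound 4 is estimated at 3000 nM, within 1200 nM to 8000 nM.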

Compound 4, inhibition constant: 420 nM
For compound 4 the middle estimate is 7.1-fold (0.85 log units) above the measured one; measured number below the stated range.
By their numbers in this assay, from the lowest: compound 1; then compound 4; then compound 2; then compound 3.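

The methoxy group is not needed for binding at this aromatic carbon: in this assay, hydrogen in its place gives a 3.8-fold lower number from compound 2 to compound 4 (0.58 log units; beyond the scatter) and so moves toward a stronger inhibitor. This is the first comparison among these compounds that changes only one place, and it shows that 2-methoxyphenyl is less favourable here than plain phenyl. No measurement shown here accounts for the gain. From the compounds shown here alone, it remains open whether chlorine or hydroxyl on this aromatic carbon would match hydrogen, and whether methoxy at another carbon of that ring would cost the same.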